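A few compounds are considered here, and "the series" means these few. Any claim that something is new, unique, unknown or untested is made for them only; others in the source may bear on it.

Measured compounds:
Compound 1 `C=CCc1ccc(OCc2cn(-c3ccccc3Cl)nn2)c(O)c1` — 58.3%
Compound 2 `C=CCc1cc(O)c(O)c(CN2CCC(CCO)CC2)c1` — 21.4%
Compound 3 `C=CCc1cc(O)c(O)c(CN2CCC(Cc3ccccc3)CC2)c1` — 70.9%

In a functional assay on MCF7 cells (Homo sapiens) for inhibition, read by MTT assay, with a stated time of 72 h, tested at 30 uM (a lower number here means less inhibition of growth, a higher number more inhibition of growth at the concentration tested), compound 1 stands second highest of the three numbers. Its nearest neighbour is compound 3, which lies beyond the scatter above it, while compound 2 lies far below it, also beyond the scatter. Among the measured compounds shown here, the only measured step within this set is a number 49.5 percentage points higher from compound 2 to compound 3 (beyond the scatter), and that step lies in a different part of the molecule, on the saturated ring attached through a saturated chain carbon, not on the aromatic nitrogen that is changed here.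

Compound 4 `C=CCc1ccc(OCc2cn(-c3ccc(Br)cc3)nn2)c(O)c1` differs from compound 1 by 4-bromophenyl in place of 2-chlorophenyl on an aromatic nitrogen. For the measured compounds named here, no measured pair shows what such an exchange on the aromatic nitrogen does to growth inhibition in this assay; the step from compound 2 to compound 3 concerns a different place and a different kind of group, so it gives no direct guide. In the absence of a comparable measured step, the expected change is none beyond the scatter, and the estimated step of a number 0.3 percentage points lower from compound 1 to compound 4 (within the scatter) is accordingly small. Compound 4 is therefore expected to give 58%, with a range from 40% to 74%.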

Compound 4, percent growth inhibition at one concentration: 19.4%
Compound 4: the middle estimate sits 38.6 percentage points above what was measured; measured number below the stated range.
By their numbers in this assay, from the lowest: compounds 4 and 2 (each within the scatter of the next); then compound 1; then compound 3.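

Among the compounds shown here, exchanging 2-chlorophenyl for 4-bromophenyl on the aromatic nitrogen gives a number 38.9 percentage points lower from compound 1 to compound 4 (beyond the scatter) in this assay, so growth inhibition responds strongly to the group at this position, which the earlier compounds could not show. The response appears even though the two groups match in heavy-atom count, each holds one six-membered aromatic ring of carbon only, and neither has a hydrogen-bond donor, a hydrogen-bond acceptor or a net charge; what differs is the halogen and where it sits on the phenyl ring. No measurement at hand bears on why the number falls with this exchange.

This single step changes the halogen and its place on the phenyl ring together, so the compounds shown cannot tell which of the two matters, or whether both do. From the compounds shown here alone, what a plain phenyl, or a phenyl carrying an amine or a carboxylic acid, would give on this aromatic nitrogen also remains open.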